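Dropping one hydroxy from an inactive catechol ester

A few compounds are considered here, and "the series" means these few. Any claim that something is new, unique, unknown or untested is made for them only; others in the source may bear on it.

Measured so far:
compound 1 `COC(=O)c1cc(C[C@H]2C(C)=CC[C@H]3C(C)(C)CCC[C@]23C)c(O)c(O)c1O`: > 10000 nM
compound 2 `C=C1CCC[C@H]2[C@](C)(CC3=C(O)C(=O)C=C(NCC(C)C)C3=O)[C@@H](C)CC[C@]12C`: > 10000 nM

Both entries in a functional assay on HeLa cells (Homo sapiens) for antiproliferative activity, read by sulforhodamine B assay, with a stated time of 72 h (on this read-out lower numbers stand for stronger inhibition and higher numbers for weaker inhibition), are limits of the assay rather than numbers. For compound 1 the read-out in this assay is a limit of > 10000 nM. For compound 2 the read-out in this assay is also a limit of > 10000 nM. Within the data shown here, the only evidence on the series is the limit of > 10000 nM in this assay, at which 2 of the 2 values shown sit, so compound 1 stands at the limit and cannot be ordered against compound 2.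

Compound 3 `COC(=O)c1cc(O)c(O)c(C[C@H]2C(C)=CC[C@H]3C(C)(C)CCC[C@]23C)c1` differs from compound 1 by hydrogen in place of hydroxy on an aromatic carbon. Among the measured compounds shown here, no step between measured compounds is available to calibrate this change. The expected step that the limit leaves unreadable from compound 1 to compound 3 is therefore none beyond the scatter, and the outcome is expected to remain a limit. Compound 3 is estimated to give 15000 nM in this assay, within 5000 nM to 50000 nM.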

Compound 3, half-maximal inhibitory concentration: > 10000 nM
Compound 3 ended at the assay's limit (the forecaster's own chance of this, stated with the estimate: 80%); the middle value lies beyond the limit too.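

Among these compounds, compound 1 and compound 3 both sit at the limit of this assay, so no step between them can be read: the limit of > 10000 nM in this assay, at which 3 of the 3 values shown sit.

The compounds shown leave open whether hydrogen in place of hydroxy on an aromatic carbon changes antiproliferative activity at all, as none gives a value inside the measurable range.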